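A few compounds are considered here, and "the series" means these few. Any claim that something is new, unique, unknown or untested is made for them only; others in the source may bear on it.

Compound 1, `COc1ccc(/C=C/C(=O)c2ccc(NC(=O)CO[N+](=O)[O-])cc2)cc1`, gives 51% in a functional assay on the whole organism (strain albino) for inhibition, with Rattus norvegicus as the target, read by paw edema, with stated times of 30 min and 4 h, at a dose of 100 mg/kg by the oral route; on this read-out lower numbers stand for less inhibition and higher numbers for more inhibition at the one dose given (going by the name of the read-out). Compound 2, `O=C(CO[N+](=O)[O-])Nc1ccc(C(=O)/C=C/c2ccco2)cc1`, gives 40%. Compound 3, `COc1ccc(/C=C/C(=O)c2ccc(NC(=O)C(C)O[N+](=O)[O-])cc2)cc1`, gives 43%.

Compound 4, `CC(O[N+](=O)[O-])C(=O)Nc1ccc(C(=O)/C=C/c2ccco2)cc1`, has not been measured. It differs from compound 3 in one place: furan-2-yl in place of 4-methoxyphenyl on a double-bonded chain carbon bound to a double-bonded chain carbon. The same change has already been made once among the measured compounds, from compound 1 to compound 2: furan-2-yl in place of 4-methoxyphenyl on a double-bonded chain carbon bound to a double-bonded chain carbon. There it gave a number 11 percentage points lower from compound 1 to compound 2 (beyond the scatter). The two places read the same word for word, so this is the same change made on a different core. The two cores differ as follows: methyl in place of hydrogen on a saturated chain carbon bound to a carbonyl carbon and an oxygen on an unsaturated carbon, and that difference gave a number 8 percentage points lower from compound 1 to compound 3 (within the scatter).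

For the measured compounds named here, since the one earlier example of this change shows a modest drop, a step of about the same size is expected from compound 3 to compound 4, namely a number 11 percentage points lower from compound 3 to compound 4 (beyond the scatter). This expectation rests on a single measured pair, so it is uncertain. For compound 4, the expected value in this assay is 32%, likely within 20% to 44%.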

Compound 4, a percentage reported as inhibition, in the whole organism at one dose (the size of the read-out at that dose, not a potency): 49%
Estimate against measurement, compound 4: 17 percentage points below, outside the stated range (above it).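

In this assay, furan-2-yl in place of 4-methoxyphenyl gives a number 6 percentage points higher from compound 3 to compound 4 (within the scatter), so the drop seen on the core of compound 1 did not carry over to the core bearing the methyl: the same change on two cores in this assay, a number 11 percentage points lower (beyond the scatter) from compound 1 to compound 2 and a number 6 percentage points higher (within the scatter) from compound 3 to compound 4, 17 percentage points apart, beyond the scatter of two such steps. The methyl change, read on the furan-2-yl compounds, gives a number 9 percentage points higher from compound 2 to compound 4 (within the scatter), and it does not match its earlier step either: the same change on two cores in this assay, a number 8 percentage points lower (within the scatter) from compound 1 to compound 3 and a number 9 percentage points higher (within the scatter) from compound 2 to compound 4, 17 percentage points apart, beyond the scatter of two such steps. Both comparisons rest on the same four compounds, so together they show one thing: in this small set, the result of either change depends on the core, and a single pair is a poor guide to the next. They do not show why, nor do they set compound 4 apart from compound 3 or compound 2, since both new steps lie within the scatter.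

Still open, on these data alone, is whether a plain phenyl or a thiophen-2-yl in the same place would follow the drop or the lack of one. An ethyl in place of the methyl raises the same question for the other change.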